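Chloro for fluoro on the aryl sulfone of compound 3

This account rests on a few compounds, and the source may have more. Where it says the series, first, only, none or still open, it means among the compounds named here.

Measured compounds:
- compound 1 `O=S(=O)(/C=C/c1cccc(Cl)n1)c1ccc(F)cc1`: 2790 nM
- compound 2 `O=S(=O)(/C=C/c1ncccc1Cl)c1ccc(Cl)cc1`: 65 nM
- compound 3 `O=S(=O)(/C=C/c1cccnc1Cl)c1ccc(F)cc1`: 339 nM

In an assay on U2OS cells for activation of nuclear factor erythroid 2-related factor 2 (Homo sapiens), read by beta-arrestin recruitment, with a stated time of 6 h (a lower number here means that less compound is needed, a higher number that more compound is needed for the effect), compound 3 gives 339 nM, the second highest of the three numbers. The nearest number is that of compound 2 at 65 nM, a gap beyond the scatter; the furthest is that of compound 1 at 2790 nM, also beyond the scatter. Compound 4 `O=S(=O)(/C=C/c1cccnc1Cl)c1ccc(Cl)cc1` is not yet measured. It differs from compound 3 in one place: chloro in place of fluoro on an aromatic carbon, on an aromatic carbon of a six-membered aromatic ring of carbon only, para to a large group. Among the compounds with values here, no measured pair shows this change alone, so the size of the step is an open question. Compound 4 is expected at about 200 nM, between 60 nM and 700 nM, a step of a 1.7-fold lower number from compound 3 to compound 4 (0.23 log units; within the scatter) that is estimated to be modest and toward a lower number, because compound 2, which also carries the chloro group, gives 65 nM.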

Compound 4, half-maximal effective concentration: 305 nM
Compound 4: middle estimate off by 1.5-fold (0.18 log units), on the low side; measured number inside the range.
By their numbers in this assay, from the lowest: compound 2; then compounds 4 and 3 (each within the scatter of the next); then compound 1.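

Within the data shown here, this is the first pair to show the change alone: in this assay, chloro in place of fluoro on an aromatic carbon, para to a large group, gives a 1.1-fold lower number from compound 3 to compound 4 (0.05 log units; within the scatter). On this core, the two halogens at this position cannot be told apart. Nothing available explains why they read alike.

As far as these compounds go, whether a methoxy group, an amine or a carboxylic acid at this position would read the same remains open. So does whether the two halogens also read alike on the differently substituted rings of compound 1 and compound 2.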